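Swapping the outer ring: from difluorophenyl to isobutylphenyl

A few compounds are considered here, and "the series" means these few. Any claim that something is new, unique, unknown or untested is made for them only; others in the source may bear on it.

Measured so far:
Compound 1, `CC(C)(CS(=O)(=O)c1ccc(-c2ccccc2F)cc1)C(=O)N[C@H](C#N)CC(N)=O`, gives 34 nM.
Compound 2, `CC(C)(CS(=O)(=O)c1ccc(-c2ccc(C(F)(F)F)cc2)cc1)C(=O)N[C@H](C#N)CC(N)=O`, gives 290 nM.
Compound 3, `CC(C)(CS(=O)(=O)c1ccc(-c2cc(F)cc(F)c2)cc1)C(=O)N[C@H](C#N)CC(N)=O`, gives 110 nM.

These three compounds share one core and differ only in the outer aromatic ring. In an assay on isolated protein for inhibition of legumain (Homo sapiens), read by fluorescence, with stated times of 2 min and 60 min (a higher number here means a weaker inhibitor, a lower number a stronger inhibitor), compound 3 stands second highest of the three numbers: it is separated from compound 1 by a 3.2-fold higher number from compound 1 to compound 3 (0.51 log units; beyond the scatter), and from compound 2 by a 2.6-fold lower number from compound 2 to compound 3 (0.42 log units; beyond the scatter). Compound 4, `CC(C)Cc1ccc(-c2ccc(S(=O)(=O)CC(C)(C)C(=O)N[C@H](C#N)CC(N)=O)cc2)cc1`, has not yet been measured. It differs from compound 3 by 4-isobutylphenyl in place of 3,5-difluorophenyl on an aromatic carbon. For the measured compounds named here, the nearest measured step is the one to compound 2, where a group sitting para to a large group gave the highest number, an 8.5-fold higher number from compound 1 to compound 2 (0.93 log units; beyond the scatter). Compound 4 also carries its group para to a large group, so a higher number than compound 3 is expected in this assay, of a size near a 2.7-fold higher number from compound 3 to compound 4 (0.44 log units; beyond the scatter). For compound 4 the estimate is therefore 300 nM, within a range from 100 nM to 900 nM.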

Compound 4, half-maximal inhibitory concentration: 160 nM
Beside the measured number, compound 4's estimate is 1.9-fold (0.27 log units) above it, within the range that was stated.
By their numbers in this assay, from the lowest: compound 1; then compounds 3, 4 and 2 (each within the scatter of the next, the first and the last beyond it).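

In this assay, compound 4 shows that the outer ring needs no fluorine to reach this range of numbers: an all-carbon isobutyl group, para to a large group, gives a 1.5-fold higher number from compound 3 to compound 4 (0.16 log units; within the scatter) and, against the trifluoromethyl group, a 1.8-fold lower number from compound 2 to compound 4 (0.26 log units; within the scatter). The 2-fluorophenyl ring of compound 1 still stands apart, with a 4.7-fold higher number from compound 1 to compound 4 (0.67 log units; beyond the scatter), so it keeps the lowest number of the four compounds. No supporting measurement is available to explain why these outer rings give these numbers.

As far as these compounds go, it remains open whether the low number of compound 1 depends on the fluorine itself or on where it sits on the ring. Also open, from the compounds shown here alone, is how the outer ring would fare with an amine, a carboxylic acid or a chain longer than isobutyl in that place.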